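The compounds below may be only part of what the source reports. "The series", "measured", "known", "first", "only" and "open" are said of these compounds alone.

Working notes on the series.

Three compounds carry a measurement in a functional assay on CHO cells for antagonist activity at sphingosine 1-phosphate receptor 2 (Homo sapiens), read by GTPgammaS binding; a higher number here means a weaker inhibitor, a lower number a stronger inhibitor. Compound 1, `O=C(O)Cn1nc(Cc2nc3cc(Cl)c(OCC(F)F)cc3[nH]2)c2ccccc2c1=O`, gives 15 nM. Compound 2, `O=C(O)Cn1nc(Cc2cn3cc(OCC4CC4)c(Cl)cc3n2)c2ccccc2c1=O`, gives 86 nM. Compound 3, `O=C(O)Cc1nn(Cc2cn3cc(OCC4CC4)c(Cl)cc3n2)c2ccccc2c1=O`, gives 30 nM. Compound 3 thus holds the second highest of the three numbers: against compound 1 the two values sit within the scatter and no order between them can be claimed, whereas the gap to compound 2 lies beyond the scatter, compound 2 showing the higher number.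

The next compound, compound 4, `C[C@H](C(=O)O)c1nn(Cc2cn3cc(OCC4CC4)c(Cl)cc3n2)c2ccccc2c1=O`, has not yet been measured in this assay. It differs from compound 3 in one place: methyl in place of hydrogen on a saturated chain carbon bound to an aromatic carbon and a carbonyl carbon. Among the measured compounds shown here, nothing measured here shows the effect of a methyl in place of hydrogen on a saturated chain carbon bound to an aromatic carbon and a carbonyl carbon, so no measured step guides the reading. In the absence of such a step, the expectation for compound 4 is a step of a 1.3-fold higher number from compound 3 to compound 4 (0.12 log units; within the scatter), that is no change beyond the scatter, with the range left wide in both directions. The estimate for compound 4 in this assay is 40 nM, expected to fall between 15 nM and 110 nM.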

Compound 4, half-maximal inhibitory concentration: 16 nM
Beside the measured number, compound 4's estimate is 2.5-fold (0.40 log units) above it, and the stated range covers the measured number.
By their numbers in this assay, from the lowest: compounds 1, 4 and 3 (each within the scatter of the next); then compound 2.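

In this assay, among the compounds shown here, the change from carboxymethyl to 1-carboxyethyl gives a 1.9-fold lower number from compound 3 to compound 4 (0.27 log units; within the scatter), the first measured step at this position, a saturated chain carbon bound to an aromatic carbon and a carbonyl carbon. The position therefore accepts a methyl in place of hydrogen with no loss beyond the scatter, although no gain can be claimed from this single step. No measurement here bears on the reason for this outcome.

The compounds shown leave open whether the position accepts more than this one methyl, for example an ethyl, a second methyl, a fluorine or a cyclopropyl on the same carbon, and how the opposite configuration of the methyl-bearing carbon would read in this assay. Also open, going by these compounds, are whether the same methyl in place of hydrogen carries over to the chain of compound 1 or compound 2, and whether a tetrazole or a primary amide could stand in place of the carboxylic acid on the 1-carboxyethyl chain of compound 4.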